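A Ketone Side Chain Replaces the Dioxolane

A few compounds are considered here, and "the series" means these few. Any claim that something is new, unique, unknown or untested is made for them only; others in the source may bear on it.

Compound 3 `C=CC(C)(C)c1[nH]c2ccc(C[C@H]3OC(C)(C)OC3(C)C)cc2c1/C=C1\NC(=O)[C@H](C)NC1=O` stands at the limit of a functional assay on A459 cells (Homo sapiens) for cytotoxicity, read by sulforhodamine B assay, with a stated time of 24 h; a lower number here means a stronger inhibitor, a higher number a weaker inhibitor. In this assay compound 3 gives > 50000 nM, which is a limit of the assay and not a number. In this assay compound 1 `C=CC(C)(C)c1[nH]c2ccc(C[C@@H](O)C(C)(C)Cl)cc2c1/C=C1\NC(=O)[C@H](C)NC1=O` gives > 50000 nM, likewise a limit. In this assay compound 2 `C=CC(C)(C)c1[nH]c2ccc(C[C@@H](O)C(=C)C)cc2c1/C=C1\NC(=O)[C@H](C)NC1=O` gives > 50000 nM, again a limit. All three values sit at the limit of > 50000 nM in this assay, at which 3 of the 3 values shown sit, so none of the three compounds can be distinguished from another by these data.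

The step to compound 4 `C=CC(C)(C)c1[nH]c2ccc(CC(=O)C(C)C)cc2c1/C=C1\NC(=O)[C@H](C)NC1=O` is isopropylcarbonyl in place of 2,2,5,5-tetramethyl-1,3-dioxolan-4-yl on a saturated chain carbon bound to an aromatic carbon. Going by the values given here, three measured steps bear on it: a step that the two limits leave unreadable from compound 1 to compound 2, a step that the two limits leave unreadable from compound 1 to compound 3 and a step that the two limits leave unreadable from compound 2 to compound 3. Among the compounds with values here, each lies between two limits and its size cannot be read; they show only that the 2-chloro-1-hydroxy-2-methylpropyl group, the 1-hydroxy-2-methylprop-2-en-1-yl group and the 2,2,5,5-tetramethyl-1,3-dioxolan-4-yl group all left the compounds without a measurable number. With no readable step in either direction, compound 4 is expected to behave like its neighbours, and the step that the limit leaves unreadable from compound 3 to compound 4 is estimated to stay within the scatter should a number appear at all. Compound 4 is therefore estimated at 60000 nM, with a range from 20000 nM to 200000 nM, and most likely reported only as a limit.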

Compound 4, half-maximal inhibitory concentration: > 50000 nM
Compound 4 was reported as a limit; the forecaster's own chance of this, stated with the estimate: 80%; the middle value is on the limit's open side.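

The steps from compound 1, compound 2 and compound 3 to compound 4 cannot be read, as all four compounds give only a limit of the assay and not a number: the limit of > 50000 nM in this assay, at which 4 of the 4 values shown sit.

The compounds shown leave open whether any of these side chains on the shared core gives a measurable number in this assay, and how far the four compounds differ.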